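Carbamate swap on a selenocyanate: from benzyl to isobutyl

This account rests on a few compounds, and the source may have more. Where it says the series, first, only, none or still open, it means among the compounds named here.

Measured so far:
compound 1, `N#C[Se]c1ccc(NC(=O)OCc2ccc([N+](=O)[O-])cc2)cc1` — 9300 nM
compound 2, `N#C[Se]c1ccc(NC(=O)OCc2ccccc2)cc1` — 23200 nM
compound 3, `O=C(Nc1ccc([Se][Se]c2ccc(NC(=O)Oc3ccccc3)cc2)cc1)Oc1ccccc1` — 22400 nM

In a functional assay on CCRF-CEM cells (Homo sapiens) for cytotoxicity, read by MTT assay, with a stated time of 72 h (a higher number here means a weaker inhibitor of growth, a lower number a stronger inhibitor of growth), compound 2 gives the highest of the three numbers, though its value and that of compound 3 lie within the scatter of each other; compound 1 is further off, and a 2.5-fold higher number from compound 1 to compound 2 (0.40 log units; beyond the scatter). Compound 4, `CC(C)COC(=O)Nc1ccc([Se]C#N)cc1`, differs from compound 2 by isopropyl in place of phenyl on a saturated chain carbon bound to an oxygen next to a carbonyl group. Among the measured compounds shown here, no measured step touches this part of the molecule: the only step on record changes a nitro group on a distant ring. With nothing to point either way, the expected change is a 1.1-fold higher number from compound 2 to compound 4 (0.03 log units; within the scatter), a step within the scatter. Compound 4 is therefore estimated at 25000 nM, with a range from 8000 nM to 70000 nM.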

Compound 4, concentration for 50% growth inhibition: 9300 nM
Compound 4: middle estimate off by 2.7-fold (0.43 log units), on the high side, and the stated range covers the measured number.
By their numbers in this assay, from the lowest: compounds 1 and 4 (each within the scatter of the next); then compounds 3 and 2 (each within the scatter of the next).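

Among the compounds shown here, until now, the only step on record changed a nitro group on the ring of this side chain, so it said nothing about whether the ring itself was needed. In this assay, replacing phenyl with isopropyl on the saturated chain carbon gives a 2.5-fold lower number from compound 2 to compound 4 (0.40 log units; beyond the scatter) and shows that growth inhibition survives, and even improves, with no aromatic ring at this place. No available measurement explains this change. On these data alone, it remains open whether a longer chain or an amine at this place would shift the number further.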